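The source may report more compounds than this note shows. Statements on the series, on what has been measured and on what is new or still open speak of the compounds shown alone.

Going by the values given here, compound 2 `Cc1ccc(Nc2cc(-c3ccccc3)oc(=O)c2)cc1` is the only member of the series with a number in a functional assay on SK-BR-3 cells (Homo sapiens) for cytotoxicity, read by MTT assay, with a stated time of 72 h (a higher number here means that more compound is needed for the effect, a lower number that less compound is needed), where compound 2 gives 0.09 uM. Compound 1 `O=c1cc(NC2CC2)cc(-c2ccccc2)o1` reaches only a limit in this assay, > 30 uM, which is a limit of the assay and not a number (the limit of > 30 uM in this assay, at which 1 of the 2 values shown sits). Compound 3 `O=c1cc(NC2CCCCC2)cc(-c2ccccc2)o1` is not yet measured; it differs from compound 2 by cyclohexyl in place of 4-methylphenyl on a nitrogen on an aromatic ring. Among the compounds with values here, the one measured step that bears on this change is an at least 330-fold lower number from compound 1 to compound 2 (2.52 log units; beyond the scatter), where a saturated ring on that nitrogen gave way to an aromatic one. Compound 3 moves the other way, from the aromatic 4-methylphenyl to a saturated cyclohexyl, so a large step to a higher number in this assay is expected, though cyclohexyl is not cyclopropyl and the size is uncertain. The expected step is an 89-fold higher number from compound 2 to compound 3 (1.95 log units; beyond the scatter). For compound 3 the estimate in this assay is 8 uM, within 0.8 uM to 30 uM.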

Compound 3, concentration for half-maximal effect: 10.9 uM
Compound 3: the middle estimate sits 1.4-fold (0.13 log units) below what was measured; low and high end bracket the measured number.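

The change to cyclohexyl on the nitrogen gives a 120-fold higher number from compound 2 to compound 3 (2.08 log units; beyond the scatter) in this assay, so compound 3 shows that a large gap from 4-methylphenyl at this position also holds for a saturated ring other than cyclopropyl. The two saturated rings do not read alike, with cyclohexyl in place of cyclopropyl giving an at least 2.7-fold lower number from compound 1 to compound 3 (0.43 log units; beyond the scatter). Compound 1 stands at a limit and not a number: the limit of > 30 uM in this assay, at which 1 of the 3 values shown sits.

Open, on these data alone, is whether the low number of compound 2 rests on the aromatic ring alone or also on its methyl group, a question that a plain phenyl on the nitrogen would address. Also open, as far as these compounds go, is how a pyridyl ring, a benzyl group or a methoxy or chloro group in place of that methyl would read in this assay.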